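Three Limits and an Unmeasured Fourth Compound

The source may hold more compounds than are shown below. What is called first, only, known or untested is meant among the compounds shown, and "the series" means these compounds.

Compound 1, `N#CC1=C(N)Oc2c(N)cc3nc4ccccc4nc3c2C12C(=O)N(Cc1cnnn1-c1ccc(F)cc1)c1ccccc12`, gives > 50000 nM in an ADME assay on HUVEC cells (Homo sapiens) for antiproliferative activity, read by MTT assay, with a stated time of 48 h; a lower number here means a stronger inhibitor, a higher number a weaker inhibitor; this is a limit of the assay, not a number.
Compound 2, `N#CC1=C(N)Oc2c(N)cc3nc4ccccc4nc3c2C12C(=O)N(Cc1cnnn1-c1ccccc1Cl)c1ccccc12`, gives > 50000 nM in this assay; this too is a limit.
Compound 3, `COc1ccc(-n2nncc2CN2C(=O)C3(C(C#N)=C(N)Oc4c(N)cc5nc6ccccc6nc5c43)c3ccccc32)cc1`, gives > 50000 nM in this assay; again a limit.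

Compound 3 therefore stands at the upper edge of what this assay reports, and it does so together with both of its measured neighbours: the limit of > 50000 nM in this assay, at which 3 of the 3 values shown sit. The three steps among the measured compounds, a step that the two limits leave unreadable from compound 1 to compound 2, a step that the two limits leave unreadable from compound 1 to compound 3 and a step that the two limits leave unreadable from compound 2 to compound 3, cannot be read in size, since each joins two limits.

Compound 4, `CCc1cccc(C)c1-n1nncc1CN1C(=O)C2(C(C#N)=C(N)Oc3c(N)cc4nc5ccccc5nc4c32)c2ccccc21`, differs from compound 3 in one place: 2-ethyl-6-methylphenyl in place of 4-methoxyphenyl on an aromatic nitrogen. The measured steps bear on this change only in the sense that exchanging one aryl group for another on that aromatic nitrogen has never moved a compound off the limit, whether the entering group carried fluoro, chloro or methoxy. Within the data shown here, no step of readable size is available, so nothing beyond the scatter can be expected in either direction.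

On that basis compound 4 is expected to remain at or beyond the limit, and its estimated value in this assay is 60000 nM, with a range from 25000 nM to 200000 nM. The step from compound 3 to compound 4 that this estimate means, a step that the limit leaves unreadable from compound 3 to compound 4, is expected to be unreadable.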

Compound 4, half-maximal inhibitory concentration: > 50000 nM
Compound 4: no number, only a limit; the forecaster's own chance of this, stated with the estimate: 85%; the middle value is on the limit's open side.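

The steps from compound 1, compound 2 and compound 3 to compound 4 cannot be read, since each joins two limits in this assay: the limit of > 50000 nM in this assay, at which 4 of the 4 values shown sit.

The compounds shown leave open how far beyond the limit each of the four lies, and whether any aryl group on that aromatic nitrogen would give a readable value in this assay.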